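Compound 3 drops the amide nitrogen of compound 2

The source may hold more compounds than are shown below. What is called first, only, known or untested is meant among the compounds shown, and "the series" means these compounds.

Compound 1 `COc1cc(Cl)cc(-c2nn(-c3cccc(NC(=O)Nc4ccc(Cl)c(C(F)(F)F)c4)c3)cc2-c2ccncc2)c1`: 28.1%
Compound 2 `COc1cc(Cl)cc(-c2nn(-c3cccc(NC(=O)Nc4cccc(C(F)(F)F)c4)c3)cc2-c2ccncc2)c1`: 16.1%

In a functional assay on SNB-19 cells (Homo sapiens) for inhibition, read by sulforhodamine B assay, with a stated time of 48 h, tested at 10 uM (on this read-out lower numbers stand for a stronger effect and higher numbers for a weaker effect at the one concentration tested), compound 2 stands lowest of the two numbers. Going by the values given here, the only measured step, a number 12 percentage points lower from compound 1 to compound 2 (beyond the scatter), concerns a chloro group elsewhere in the molecule. Compound 3 `COc1cc(Cl)cc(-c2nn(-c3cccc(NC(=O)c4cccc(C(F)(F)F)c4)c3)cc2-c2ccncc2)c1` differs from compound 2 by 3-(trifluoromethyl)phenyl in place of (3-(trifluoromethyl)phenyl)amino on a carbonyl carbon. Among the compounds with values here, no measured step touches this change, so there is no guide for its size or direction. Compound 3 is therefore expected near the value of compound 2, with a wide range: an estimate of 22%, between 5% and 55%, meaning an expected step of a number 5.9 percentage points higher from compound 2 to compound 3 (within the scatter) not beyond the scatter.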

Compound 3, a percentage reported as activity, at one concentration (the size of the read-out at that concentration, not a potency): 82.2%
Compound 3: the middle estimate sits 60.2 percentage points below what was measured; measured number outside the range, above it.
By their numbers in this assay, from the lowest: compound 2; then compound 1; then compound 3.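

In this assay the nitrogen on the carbonyl carbon proves far more sensitive than the chloro position: 3-(trifluoromethyl)phenyl in place of (3-(trifluoromethyl)phenyl)amino gives a number 66.1 percentage points higher from compound 2 to compound 3 (beyond the scatter), a much larger step than any seen before. Measured against the chloro-bearing partner, the same kind of replacement gives a number 54.1 percentage points higher from compound 1 to compound 3 (beyond the scatter), in the same direction. No available evidence accounts for this loss. From the compounds shown here alone, whether an oxygen atom or a methylene group in place of that nitrogen would keep the lower number remains open, as does the effect of the chloro group once the nitrogen is gone.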